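Iodo for isopropyl on an aryl sulfonate urea

The source may report more compounds than this note shows. Statements on the series, on what has been measured and on what is new or still open speak of the compounds shown alone.

Measured compounds:
compound 1, `CCNC(=O)Nc1ccc(S(=O)(=O)Oc2ccccc2I)cc1`, 5300 nM
compound 2, `CCCNC(=O)Nc1ccc(S(=O)(=O)Oc2ccccc2C(C)C)cc1`, 6300 nM

Of the compounds shown here, two have been tested in a functional assay on HT-29 cells (Homo sapiens) for antiproliferative activity, read by sulforhodamine B assay, with a stated time of 48 h; on this read-out lower numbers stand for stronger inhibition and higher numbers for weaker inhibition. Compound 1 gives 5300 nM in this assay. Compound 2 gives 6300 nM, which is the highest of the two numbers, though the gap to compound 1 falls within the usual scatter, so the two cannot be placed in an order. Compound 1 and compound 2 differ in more than one place, so their values show only that both lie in the same region.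

Compound 3, `CCCNC(=O)Nc1ccc(S(=O)(=O)Oc2ccccc2I)cc1`, has not yet been measured. It differs from compound 2 in one place: iodo in place of isopropyl on an aromatic carbon, the aromatic carbon sitting ortho to a large group. The same iodo group is already present in compound 1, whose value is close to that of compound 2. For the measured compounds named here, no measured pair isolates this change, so the size of the step in this assay is not known; any step is expected to stay within the scatter, without a clear direction.

Compound 3 is therefore expected to give 5500 nM, within a range from 2500 nM to 12000 nM. This estimate means a step of a 1.1-fold lower number from compound 2 to compound 3 (0.06 log units; within the scatter), which is not expected to rise above the scatter.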

Compound 3, half-maximal inhibitory concentration: 6800 nM
The estimate for compound 3 lay 1.2-fold (0.09 log units) below the measured number; low and high end bracket the measured number.
By their numbers in this assay, from the lowest: compounds 1, 2 and 3 (each within the scatter of the next).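

In this assay, the change from isopropyl to iodo on an aromatic carbon ortho to a large group now has a measured pair of its own, which gives a 1.1-fold higher number from compound 2 to compound 3 (0.03 log units; within the scatter) and shows that, with the rest of the structure held constant, the two groups are not told apart in this read-out, although isopropyl has three heavy atoms and iodo one. A second pair, also new, isolates methyl in place of hydrogen on a saturated chain carbon, two bonds along the chain from an amide-type nitrogen, and gives a 1.3-fold higher number from compound 1 to compound 3 (0.11 log units; within the scatter) with the iodo group in place, so neither single change moves the number beyond the scatter. Nothing measured here offers an explanation for either result.

The compounds shown leave open whether a hydrogen, a methoxy group or a carboxylic acid on that same aromatic carbon would stay in this region of values. They also leave open whether a longer chain such as butyl, or a chain ending in an amine, would keep the number there.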